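Swapping a propyl for furan-2-yl in cytotoxicity screening

A few compounds are considered here, and "the series" means these few. Any claim that something is new, unique, unknown or untested is made for them only; others in the source may bear on it.

Measured so far:
Compound 1, `CCCCC(=O)Nc1nnc(-c2ccc([N+](=O)[O-])cc2)s1`, gives 278000 nM in an ADME assay on Vero cells (Chlorocebus sabaeus) for cytotoxicity, read by MTT assay, with a stated time of 72 h; on this read-out higher numbers stand for weaker inhibition and lower numbers for stronger inhibition.
Compound 2, `CCCC(=O)Nc1nnc(-c2ccc([N+](=O)[O-])cc2)s1`, gives 301000 nM in this assay.

Going by the values given here, compound 2 holds the highest of the two numbers in this assay, but its only neighbour is compound 1, and the gap between them is small: a 1.1-fold higher number from compound 1 to compound 2 (0.03 log units; within the scatter). Both compounds thus sit at the weak end of the read-out, with no real separation between them.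

Compound 3, `O=C(Nc1nnc(-c2ccc([N+](=O)[O-])cc2)s1)c1ccco1`, has not yet been measured. It differs from compound 2 in one place: furan-2-yl in place of propyl on a carbonyl carbon. Among the compounds with values here, the only step measured so far, from compound 1 to compound 2, removes one carbon from a saturated chain and stays within the scatter; it says little about replacing the whole chain with an aromatic ring. With nothing pointing up or down, the expectation for compound 3 in this assay is a step of about a 1.2-fold lower number from compound 2 to compound 3 (0.08 log units; within the scatter), which is no movement beyond the scatter. Compound 3 is therefore estimated at 250000 nM in this assay, within a range of 100000 nM to 600000 nM.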

Compound 3, half-maximal inhibitory concentration: 306000 nM
Estimate against measurement, compound 3: 1.2-fold (0.09 log units) below, within the range that was stated.
By their numbers in this assay, from the lowest: compounds 1, 2 and 3 (each within the scatter of the next).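

On the carbonyl carbon whose other neighbour is the amide-type nitrogen, a saturated chain and an aromatic ring read alike in this cytotoxicity screen (this assay), with furan-2-yl in place of propyl giving (a 1.0-fold higher number from compound 2 to compound 3 (0.01 log units; within the scatter)) and furan-2-yl in place of butyl giving (a 1.1-fold higher number from compound 1 to compound 3 (0.04 log units; within the scatter)). The earlier step only shortened a saturated chain, whereas this change brings in a five-membered aromatic ring, replaces the 3 heavy atoms of propyl with 5, and adds a hydrogen-bond acceptor, yet both new steps stay within the scatter. Nothing available helps to explain why these different groups give such similar readings.

The three compounds share the same core and differ only in this one group, so they cannot show what the rest of the structure contributes to the reading. From the compounds shown here alone, it also remains open whether an amine, a carboxylic acid or a longer chain on this carbonyl carbon would move the number beyond the scatter.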